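Chloro for fluoro on the aryl of a pyrazole series

A few compounds are considered here, and "the series" means these few. Any claim that something is new, unique, unknown or untested is made for them only; others in the source may bear on it.

Measured so far:
compound 1 `O=C(NC(=S)Nc1ccc(F)cc1)c1cn(-c2ccccc2)nc1-c1ccc(F)cc1` — 5610 nM
compound 2 `COc1ccc(NC(=S)NC(=O)c2cn(-c3ccccc3)nc2-c2ccc(OC)cc2)cc1` — 4210 nM

In a functional assay on MCF7 cells (Homo sapiens) for inhibition, read by CCK-8 assay, with a stated time of 48 h (on this read-out higher numbers stand for weaker inhibition and lower numbers for stronger inhibition), compound 1 gives 5610 nM, and compound 2 gives 4210 nM; the two numbers lie within the usual scatter of one another, so neither stands apart. Compound 3 `O=C(NC(=S)Nc1ccc(F)cc1)c1cn(-c2ccccc2)nc1-c1ccc(Cl)cc1` is not yet measured. It differs from compound 1 in one place: chloro in place of fluoro on an aromatic carbon. Within the data shown here, no step between measured compounds guides this change, so the step of a 1.2-fold lower number from compound 1 to compound 3 (0.10 log units; within the scatter) is expected to be small, not clearly beyond the scatter. Compound 3 is therefore estimated at 4500 nM, with a range from 2000 nM to 10000 nM.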

Compound 3, half-maximal inhibitory concentration: 5990 nM
For compound 3 the middle estimate is 1.3-fold (0.12 log units) below the measured one; measured number inside the range.
By their numbers in this assay, from the lowest: compounds 2, 1 and 3 (each within the scatter of the next).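

In this assay, 4-fluorophenyl to 4-chlorophenyl gives a 1.1-fold higher number from compound 1 to compound 3 (0.03 log units; within the scatter) and is the only one-place step shown, so at this position the two halogens cannot be told apart on this read-out. No measurement on hand accounts for this result. Still open, going by these compounds, is whether a group of another kind at this aromatic carbon, such as an amine or a carboxylic acid, would give a step beyond the scatter. Also open, on these data alone, is whether chloro in place of the other fluoro of compound 1 would behave the same way.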